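Swapping the halogenated benzyl on a triazole: from chloro to fluoro

A few compounds are considered here, and "the series" means these few. Any claim that something is new, unique, unknown or untested is made for them only; others in the source may bear on it.

Measured so far:
Compound 1, `Cc1ccc(/C=C2\CN(C(=S)SCc3cn(Cc4ccccc4F)nn3)C/C(=C\c3ccc(C)cc3)C2=O)cc1`, gives 80000 nM in a functional assay on DU-145 cells (Homo sapiens) for cytotoxicity, read by MTT assay, with a stated time of 24 h; a higher number here means a weaker inhibitor, a lower number a stronger inhibitor.
Compound 2, `COc1ccc(/C=C2\CN(Cc3cn(Cc4cccc(Cl)c4)nn3)C/C(=C\c3ccc(OC)cc3)C2=O)cc1`, gives 15400 nM in this assay.

Compound 2 has the lowest number of the two, and the gap to compound 1 lies beyond the usual scatter of this assay. The two share a core but differ in several places at once, so no single change can be read from that pair.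

Among the measured compounds shown here, compound 3, `COc1ccc(/C=C2\CN(Cc3cn(Cc4ccc(F)cc4)nn3)C/C(=C\c3ccc(OC)cc3)C2=O)cc1`, keeps the core of compound 2 and changes only one group: 4-fluorophenyl in place of 3-chlorophenyl on a saturated chain carbon bound to an aromatic nitrogen. Put another way, a 3-chlorobenzyl becomes a 4-fluorobenzyl. For the measured compounds named here, no measured pair shows this kind of change, so no size can be read from the data. The expected step of a 1.3-fold higher number from compound 2 to compound 3 (0.11 log units; within the scatter) is small, most likely within the scatter, leaning if anything toward a somewhat higher number. Compound 3 is therefore estimated at 20000 nM, with a range from 7000 nM to 60000 nM.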

Compound 3, half-maximal inhibitory concentration: 59400 nM
Estimate against measurement, compound 3: 3.0-fold (0.47 log units) below; measured number inside the range.
By their numbers in this assay, from the lowest: compound 2; then compounds 3 and 1 (each within the scatter of the next).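

Among the compounds shown here, compound 2 and compound 3 are the first pair here that differ in one place only, so a single change can now be read. In this assay a 3-chlorobenzyl becoming a 4-fluorobenzyl gives a 3.9-fold higher number from compound 2 to compound 3 (0.59 log units; beyond the scatter) with the rest of the molecule unchanged, so a modest step beyond the scatter shows that the read-out responds to what this benzyl group carries. No measurement shown here bears on why the number moves.

The halogen and its place on the ring changed together in this one step, and the two compounds cannot tell their shares apart. As far as these compounds go, a 4-chlorobenzyl, a 3-fluorobenzyl or a plain benzyl at this position would be the groups to compare, and how far the step carries over to other cores also stays open.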